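From Amino to Hydroxy: Expected Solubility of Compound 4

A few compounds are considered here, and "the series" means these few. Any claim that something is new, unique, unknown or untested is made for them only; others in the source may bear on it.

Compound 1 `COc1ccc(-c2cc(-c3ccc(S(C)(=O)=O)cc3)cnc2N)cn1` gives the highest number of the three measured in a physicochemical assay for solubility, measured as kinetic solubility, at pH 6.5 (a higher number here means a more soluble compound, a lower number a less soluble compound), at 121 ug/mL. Compound 3 `COc1ccc(-c2cc(-c3ccc(S(C)(=O)=O)cc3)cnc2NCCCCN)cn1` gives 25 ug/mL, and compound 2 `COc1ccc(-c2nc(-c3ccc(S(C)(=O)=O)cc3)cnc2N)cn1` gives 6.3 ug/mL. For the measured compounds named here, the only single-site step measured is a 4.8-fold lower number from compound 1 to compound 3 (0.68 log units; beyond the scatter). Compound 4 `COc1ccc(-c2cc(-c3ccc(S(C)(=O)=O)cc3)cnc2O)cn1` differs from compound 1 by hydroxy in place of amino on an aromatic carbon. Going by the values given here, no measured step covers this particular exchange, so the step from compound 1 to compound 3 serves only as a loose guide to how far a single small change on the shared core can move this assay. A modest decrease is therefore expected, roughly a 2.4-fold lower number from compound 1 to compound 4 (0.38 log units; beyond the scatter), placing compound 4 near 50 ug/mL with a likely range of 15 ug/mL to 150 ug/mL.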

Compound 4, solubility: 25 ug/mL
Beside the measured number, compound 4's estimate is 2.0-fold (0.30 log units) above it; the measured number falls inside the stated range.
By their numbers in this assay, from the lowest: compound 2; then compounds 3 and 4 (each within the scatter of the next); then compound 1.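

On this aromatic carbon next to the ring nitrogen, hydroxy in place of amino gives a 4.8-fold lower number from compound 1 to compound 4 (0.68 log units; beyond the scatter) in this assay even though the counts of hydrogen-bond donors and acceptors stay the same. Hydroxy in place of (4-aminobutyl)amino gives no change at the digits printed from compound 3 to compound 4 (within the scatter) and so leaves amino with the highest number of the three groups tried here. As far as these compounds go, whether methoxy or a carboxylic acid on this carbon would come closer to amino remains open, as does whether the same exchange behaves alike on the core of compound 2. No measurement shown gives a reason for these steps.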